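The source may report more compounds than this note shows. Statements on the series, on what has been measured and on what is new or still open speak of the compounds shown alone.

Compound 2 `Cc1cccc(C)c1NC(=O)/C=C/C(=O)N1C/C(=C\c2ccccc2)C(=O)/C(=C/c2ccccc2)C1` gives in a functional assay on L1210 cells (Mus musculus) for cytotoxicity (a higher number here means a weaker inhibitor, a lower number a stronger inhibitor), a value of 22000 nM, the highest of the three numbers measured. Compound 1 `COc1ccc(NC(=O)/C=C/C(=O)N2C/C(=C\c3ccc([N+](=O)[O-])cc3)C(=O)/C(=C/c3ccc([N+](=O)[O-])cc3)C2)cc1` gives 2900 nM, and compound 3 `CC(=O)c1ccc(NC(=O)/C=C/C(=O)N2C/C(=C\c3ccc([N+](=O)[O-])cc3)C(=O)/C(=C/c3ccc([N+](=O)[O-])cc3)C2)cc1` gives 1400 nM. Within the data shown here, the only step between measured compounds that differ in one place is the change from compound 1 to compound 3, acetyl in place of methoxy on an aromatic carbon, which moved the number by a 2.1-fold lower number from compound 1 to compound 3 (0.32 log units; beyond the scatter).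

Compound 4 `O=C(/C=C/C(=O)N1C/C(=C\c2ccccc2)C(=O)/C(=C/c2ccccc2)C1)Nc1ccccc1` differs from compound 2 in one place: phenyl in place of 2,6-dimethylphenyl on an amide-type nitrogen. Among the measured compounds shown here, no measured pair shows this change, and compounds 1 and 3 differ from compound 2 in two places, so they give no direct guide. With no step bearing on the change, the size of any move in this assay cannot be drawn from the data shown; the expectation is a small step, possibly a lower number, since compound 2 leaves room for movement in that direction from 22000 nM. The expected step from compound 2 to compound 4 is therefore a 1.5-fold lower number from compound 2 to compound 4 (0.17 log units; within the scatter). Compound 4 is estimated at 15000 nM, within a range from 5000 nM to 50000 nM.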

Compound 4, half-maximal inhibitory concentration: 3600 nM
Compound 4: middle estimate off by 4.2-fold (0.62 log units), on the high side; the whole stated range lies above it.
By their numbers in this assay, from the lowest: compound 3; then compounds 1 and 4 (each within the scatter of the next); then compound 2.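

In this assay, phenyl in place of 2,6-dimethylphenyl on an amide-type nitrogen gives a 6.1-fold lower number from compound 2 to compound 4 (0.79 log units; beyond the scatter) and so shows that this nitrogen's aromatic group can move the number beyond the scatter. The earlier step changed only a group on an aromatic carbon and could not show this. Both groups here are a six-membered aromatic ring of carbon only with no hydrogen-bond donors, acceptors or net charge, and no measurement at hand explains the step.

As far as these compounds go, it remains open whether a single methyl group on the phenyl would give part of this step, and how a chlorine, an amine or a carboxylic acid there would read. Also open, from the compounds shown here alone, is whether the same change would give a similar step on the core of compound 1.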